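Mirror-image cyclopropane amide of a trimethoxyphenyl series

The source may report more compounds than this note shows. Statements on the series, on what has been measured and on what is new or still open speak of the compounds shown alone.

Compound 1 `CCOC(=O)C1(C(=O)NCc2ccc(C)cc2)CC1c1cc(OC)c(OC)c(OC)c1`: > 100000 nM; 37900 nM (2 entries)
Compound 2 `CCOC(=O)[C@]1(C(=O)Nc2ccccc2)C[C@@H]1c1cc(OC)c(OC)c(OC)c1`: 38100 nM
Compound 3 `CCOC(=O)[C@@]1(C(=O)NCc2ccc(C)cc2)C[C@H]1c1cc(OC)c(OC)c(OC)c1`: 26400 nM

In a functional assay on QGY cells (Homo sapiens) for cytotoxicity, read by MTT assay, with a stated time of 48 h (a higher number here means a weaker inhibitor, a lower number a stronger inhibitor), compound 1 gives > 100000 nM; 37900 nM (2 entries), two entries that do not agree with each other (the several entries of compound 1 in this assay, > 100000 nM; 37900 nM (2 entries)). Compound 2 gives 38100 nM in this assay. Compound 3 gives 26400 nM; its number and that of compound 2 lie within the scatter of each other, so no order between them can be read. Compound 1 shares the atoms and bonds of compound 3 but is drawn without a defined configuration (the fact that one of compounds 1 and 3 is drawn with a defined configuration and the other without, at the place where they differ).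

Compound 4 `CCOC(=O)[C@]1(C(=O)NCc2ccc(C)cc2)C[C@@H]1c1cc(OC)c(OC)c(OC)c1` differs from compound 3 only as follows: the two compounds have the same atoms and bonds and differ only in configuration as drawn: 2 of 2 stereo elements differ (all stereocentres are inverted: mirror images); a stereocentre at a saturated ring carbon is drawn S in compound 3 and R in compound 4; a stereocentre at a saturated ring carbon is drawn S in compound 3 and R in compound 4. Going by the values given here, with no measured step of this kind among the compounds, an expectation must rest on the two forms of compound 1 alongside compound 3. On that basis compound 4 is expected to give a somewhat higher number than compound 3 in this assay, a step of a 2.1-fold higher number from compound 3 to compound 4 (0.32 log units; beyond the scatter) that may or may not exceed the scatter. Compound 4 is estimated at 55000 nM, within 20000 nM to 150000 nM.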

Compound 4, half-maximal inhibitory concentration: > 100000 nM
Compound 4: only a limit was reported; the forecaster's own chance of this, stated with the estimate: 30%; middle value at least 1.8-fold (0.25 log units) away from the limit.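

In this assay compound 4 gives > 100000 nM, which is a limit of the assay and not a number. Even so, the series now has its first readable effect of configuration alone, with an at least 3.7-fold higher number from compound 3 to compound 4 (0.57 log units; beyond the scatter): the fact that compounds 3 and 4 differ only in the configuration as drawn. With the configuration of compound 4 kept, 4-methylbenzyl in place of phenyl on the amide-type nitrogen goes with an at least 2.6-fold higher number from compound 2 to compound 4 (0.41 log units; beyond the scatter), so this change can be read only in the configuration drawn for compounds 2 and 4.

On these data alone, the full size of both steps stays open, and the two disagreeing entries of compound 1 cannot be tied to either mirror-image form: the several entries of compound 1 in this assay, > 100000 nM; 37900 nM (2 entries). As far as these compounds go, it is also open whether the gap between compound 3 and compound 4 would persist with a carboxylic acid on the shared core.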